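The source may hold more compounds than are shown below. What is called first, only, known or untested is meant among the compounds shown, and "the series" means these compounds.

Compound 1, `C#CCSc1nc(Nc2cccc(C(F)(F)F)c2)c(C#N)c(-c2ccccc2)n1`, gives > 128000 nM in a functional assay on ECa-109 cells (Homo sapiens) for inhibition, read by MTT assay, with a stated time of 72 h (on this read-out lower numbers stand for stronger inhibition and higher numbers for weaker inhibition), a limit of the assay rather than a number.
Compound 2, `C#CCSc1nc(Nc2cccc(Cl)c2)c(C#N)c(-c2ccccc2)n1`, gives > 128000 nM in this assay, also a limit of the assay.
Compound 3, `N#Cc1c(Nc2ccc(Cl)cc2)nc(SCc2cn(Cc3ccccc3Cl)nn2)nc1-c1ccccc1`, gives 1420 nM in this assay.

Among the measured compounds shown here, of the three measured compounds, compound 3 is the only one with a real number in this assay; the other two values are limits. The step that the two limits leave unreadable from compound 1 to compound 2 is therefore unreadable, because both its ends sit at the limit of > 128000 nM in this assay, at which 2 of the 3 values shown sit.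

Compound 4, `N#Cc1c(Nc2ccccc2)nc(SCc2cn(Cc3ccccc3Cl)nn2)nc1-c1ccccc1`, has not yet been measured. It differs from compound 3 by hydrogen in place of chloro on an aromatic carbon, a hydrogen in place of chloro on an aromatic carbon, which turns the (4-chlorophenyl)amino group into an anilino group.

For the measured compounds named here, no measured step bears directly on this change. Going by the values given here, the one step that exists, from compound 1 to compound 2, concerns a different substituent and gives no size, so nothing among the measured compounds tells how removing this chloro will move the number. With no guide, the expectation is for compound 4 to sit close to compound 3, and the change a 1.8-fold higher number from compound 3 to compound 4 (0.25 log units; within the scatter) is expected to be small in this assay. Compound 4 is estimated at 2500 nM, within a range from 800 nM to 10000 nM.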

Compound 4, half-maximal inhibitory concentration: > 64000 nM
Compound 4: a limit, no number; the forecaster's own chance of this, stated with the estimate: 10%; middle value at least 25-fold (1.40 log units) from the limit.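

In this assay, the chloro of the 4-chlorophenyl group proves to matter a great deal: replacing this single atom with hydrogen gives an at least 45-fold higher number from compound 3 to compound 4 (1.65 log units; beyond the scatter). The result for compound 4 is a limit of the assay and not a number: the limit of > 64000 nM in this assay, at which 1 of the 4 values shown sits. Among the compounds shown here, the one earlier step, from trifluoromethyl to chloro in another pair of compounds, cannot be read, so this is the first readable evidence that a change on an aromatic carbon, para to a large group, can separate a compound with a measurable value from one that reaches a limit.

Going by these compounds, with only chloro and hydrogen compared at this place, it remains open whether a fluoro, a bromo, a methyl or a methoxy group would keep the number of compound 3 or lose it as hydrogen does. On these data alone, compound 3 also differs from compound 1 and compound 2 in more than one place, so the contribution of its larger side chain on sulfur, compared with their shorter propargyl group, remains open too.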